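Acid to tetrazole exchange at the end of the chain

The source may report more compounds than this note shows. Statements on the series, on what has been measured and on what is new or still open speak of the compounds shown alone.

Compound 2 `CCc1cc(C(C)=O)c(O)cc1OCCCCCCC(=O)O` closes its chain with a carboxy group; in an assay on isolated protein for inhibition of leukotriene B4 receptor 1 (Homo sapiens), tested at 10 uM (a lower number here means less inhibition, a higher number more inhibition at the concentration tested (going by the name of the read-out)), compound 2 gives 87%. Compound 1 `CCc1cc(C(C)=O)c(O)cc1OCCCC(C)(C)c1nnn[nH]1` gives 100% in this assay. Compound 2 thus stands lowest of the two numbers shown, with compound 1 nearest, higher by a step beyond the scatter.

Compound 3 `CCc1cc(C(C)=O)c(O)cc1OCCCCCCc1nnn[nH]1` has not been measured yet. 1H-tetrazol-5-yl in place of carboxy on a saturated chain carbon, six bonds along the chain from an oxygen on an aromatic ring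

Among the compounds with values here, one measured step bears on this change: a number 13 percentage points lower from compound 1 to compound 2 (beyond the scatter), where 3-carboxypropyl took the place of 1-(1H-tetrazol-5-yl)-1-methylethyl. The change from compound 2 to compound 3 runs the other way, carboxy to 1H-tetrazol-5-yl, though further out along the chain and without the 1-methylethyl branching of compound 1, so a step of comparable size in the upward direction is expected, a number 10 percentage points higher from compound 2 to compound 3 (within the scatter), modest but beyond the scatter. The value of compound 3 in this assay is therefore estimated at 97%, within a range from 85% to 100%.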

Compound 3, a percentage reported as inhibition, at one concentration (the size of the read-out at that concentration, not a potency): 91%
Estimate against measurement, compound 3: 6 percentage points above; the measured number falls inside the stated range.
By their numbers in this assay, from the lowest: compounds 2, 3 and 1 (each within the scatter of the next, the first and the last beyond it).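

In this assay, 1H-tetrazol-5-yl in place of carboxy, on a saturated chain carbon, six bonds along the chain from an oxygen on an aromatic ring, gives a number 4 percentage points higher from compound 2 to compound 3 (within the scatter), so on this unbranched chain the read-out does not separate the two end groups. Within the data shown here, the other new comparison, 3-(1H-tetrazol-5-yl)propyl in place of 1-(1H-tetrazol-5-yl)-1-methylethyl, gives a number 9 percentage points lower from compound 1 to compound 3 (within the scatter), so the branched and unbranched tetrazole chains are not separated either, while the earlier a number 13 percentage points lower from compound 1 to compound 2 (beyond the scatter), the only step here beyond the scatter, changes end group and chain together and now divides into two parts that each lie within the scatter. Nothing available here accounts for these numbers.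

With one tested concentration and three compounds, any difference in potency among them remains unresolved. From the compounds shown here alone, how an amine or a primary carboxamide at the chain end, or a longer chain carrying the tetrazole, would read in this assay remains open.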